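Swapping 2,4-difluorophenyl for 3,5-difluorophenyl

This account rests on a few compounds, and the source may have more. Where it says the series, first, only, none or still open, it means among the compounds named here.

In a functional assay with Homo sapiens as the target (on this read-out lower numbers stand for stronger inhibition and higher numbers for weaker inhibition), compound 1 `CC(C)[C@H](NC(=O)COc1cccc2ccccc12)C(=O)N[C@@H](CC(=O)O)C(=O)COc1ccccc1` gives 11200 nM and compound 2 `CC(C)[C@H](NC(=O)COc1cccc2ccccc12)C(=O)N[C@@H](CC(=O)O)C(=O)COc1ccc(F)cc1F` gives 17600 nM, so compound 2 stands within the scatter of compound 1. Compound 3 `CC(C)[C@H](NC(=O)COc1cccc2ccccc12)C(=O)N[C@@H](CC(=O)O)C(=O)COc1cc(F)cc(F)c1` carries 3,5-difluorophenyl in place of 2,4-difluorophenyl on an oxygen on a saturated carbon. Among the compounds with values here, the only measured step bearing on this change, a 1.6-fold higher number from compound 1 to compound 2 (0.20 log units; within the scatter), introduced 2,4-difluorophenyl in place of phenyl at that same place and stayed within the scatter. No step beyond the scatter is therefore expected, and the estimated step is a 1.2-fold lower number from compound 2 to compound 3 (0.07 log units; within the scatter). Compound 3 is expected to read 15000 nM, within an estimated range of 7000 nM to 32000 nM.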

Compound 3, half-maximal inhibitory concentration: 15900 nM
The estimate for compound 3 lay 1.1-fold (0.03 log units) below the measured number; the measured number falls inside the stated range.
By their numbers in this assay, from the lowest: compounds 1, 3 and 2 (each within the scatter of the next).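

In this assay there is a 1.1-fold lower number from compound 2 to compound 3 (0.04 log units; within the scatter) and also a 1.4-fold higher number from compound 1 to compound 3 (0.15 log units; within the scatter) with 3,5-difluorophenyl on the oxygen. A second arrangement of the same two fluorines on this ring therefore also stays within the scatter of the unsubstituted phenyl, and compound 1, compound 2 and compound 3 cannot be ordered at this place.

Going by these compounds, whether an amine or a carboxylic acid on this phenyl ring would shift the number beyond the scatter stays open. No evidence bears on what lies behind these results.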